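The compounds below may be only part of what the source reports. "The series", "measured", "known", "first", "only" and "open" are said of these compounds alone.

Of the compounds shown here, three sharing one core have been measured in a functional assay on HeLa cells (Homo sapiens) for cytotoxicity, read by sulforhodamine B assay, with a stated time of 48 h; on this read-out lower numbers stand for stronger inhibition and higher numbers for weaker inhibition. Compound 1 `O=c1cc(-c2ccccc2)oc2cc(OCCCCNc3nc4ccc([N+](=O)[O-])cc4s3)cc(O)c12` gives 6.44 ug/mL. Compound 2 `O=c1cc(-c2ccccc2)oc2cc(OCCCCNc3nc4ccc(Cl)cc4s3)cc(O)c12` gives 5.95 ug/mL. Compound 3 `O=c1cc(-c2ccccc2)oc2cc(OCCCCNc3nc4ccc(F)cc4s3)cc(O)c12` gives 5.03 ug/mL, the lowest of the three numbers, though its steps to the other two are small: a 1.3-fold lower number from compound 1 to compound 3 (0.11 log units; within the scatter) and a 1.2-fold lower number from compound 2 to compound 3 (0.07 log units; within the scatter), both within the scatter, so no order among the three can be read from them.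

The next compound, compound 4 `O=c1cc(-c2ccccc2)oc2cc(OCCCCNc3nc4ccc(C(F)(F)F)cc4s3)cc(O)c12`, differs from compound 3 in one place: trifluoromethyl in place of fluoro on an aromatic carbon. Going by the values given here, three measured steps bear on this change, since each of them also exchanges one group at the same aromatic carbon of the fused ring system: a 1.1-fold lower number from compound 1 to compound 2 (0.03 log units; within the scatter), a 1.3-fold lower number from compound 1 to compound 3 (0.11 log units; within the scatter) and a 1.2-fold lower number from compound 2 to compound 3 (0.07 log units; within the scatter). None of them moves the number beyond the scatter, whether the group that enters is nitro, chloro or fluoro.

On that basis the step from compound 3 to compound 4 is expected to stay within the scatter as well, that is a 1.1-fold higher number from compound 3 to compound 4 (0.04 log units; within the scatter). For compound 4 in this assay the estimate is therefore 5.5 ug/mL, with a range from 3 ug/mL to 10 ug/mL.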

Compound 4, half-maximal inhibitory concentration: 7.84 ug/mL
The estimate for compound 4 lay 1.4-fold (0.15 log units) below the measured number; measured number inside the range.
By their numbers in this assay, from the lowest: compounds 3, 2, 1 and 4 (each within the scatter of the next).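

Trifluoromethyl is the first group in this series with more than one heavy atom at this aromatic carbon, carrying four where fluoro carries one, and in this assay the exchange still stays within the scatter (a 1.6-fold higher number from compound 3 to compound 4 (0.19 log units; within the scatter)). The same holds when trifluoromethyl is set against the other two groups, both against chloro (a 1.3-fold higher number from compound 2 to compound 4 (0.12 log units; within the scatter)) and against nitro (a 1.2-fold higher number from compound 1 to compound 4 (0.09 log units; within the scatter)). The four groups seen at this carbon therefore cannot be put in any order, and the position has so far tolerated this larger group as well as the single halogen atoms, with the exchange from fluoro giving the widest step yet seen here, though one still inside the scatter.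

What these compounds leave open is whether any group at this carbon can move the number beyond the scatter, for example an amine or a carboxylic acid, or whether a longer chain in place of the four-carbon link would matter more than any exchange on the aromatic ring. No measurement at hand speaks to why the numbers stay so close together.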